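Removing a Trifluoromethyl Group from a Weak Benzamide

A few compounds are considered here, and "the series" means these few. Any claim that something is new, unique, unknown or untested is made for them only; others in the source may bear on it.

In a functional assay on MDA-MB-468 cells (Homo sapiens) for antiproliferative activity, read by MTT assay, with a stated time of 72 h (a higher number here means a weaker inhibitor, a lower number a stronger inhibitor), compound 1 `O=C(Nc1ccc(Cl)c(-c2nnc3c(Cl)cccn23)c1)c1ccc(C(F)(F)F)cc1Cl` gives > 100000 nM, and this is a limit of the assay rather than a measured number (the limit of > 100000 nM in this assay, at which 1 of the 2 values shown sits). Compound 2 `O=C(Nc1ccc(Cl)c(-c2nnc3c(Cl)cccn23)c1)c1cccc(Cl)c1` gives 54800 nM in this assay. Compound 3 `O=C(Nc1ccc(Cl)c(-c2nnc3c(Cl)cccn23)c1)c1ccccc1Cl` differs from compound 1 by hydrogen in place of trifluoromethyl on an aromatic carbon. Going by the values given here, no measured pair shows this change, and compound 1 stands at a limit, so only a gain beyond the scatter could be seen at all. The expected step of an at least 1.2-fold lower number from compound 1 to compound 3 (0.09 log units; that floor lies within the scatter) is a modest gain, with a fair chance that only a limit is reported again. Compound 3 is estimated at 80000 nM, within the range 30000 nM to 250000 nM.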

Compound 3, half-maximal inhibitory concentration: > 100000 nM
Compound 3 ended at the assay's limit; the forecaster's own chance of this, stated with the estimate: 45%; middle value at least 1.2-fold (0.09 log units) from the limit.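

Taking away the trifluoromethyl group is not enough on its own to give a measurable number, so the step between compound 1 and compound 3 cannot be read: the limit of > 100000 nM in this assay, at which 2 of the 3 values shown sit.

The change to 2-chlorophenyl in place of 3-chlorophenyl gives an at least 1.8-fold higher number from compound 2 to compound 3 (0.26 log units; that floor lies within the scatter), so no firm loss can be claimed for it. Compound 2 remains the only one of the three with a measured number.

Going by these compounds, whether an amine or a carboxylic acid on this aromatic carbon would give a measurable number stays open. So does how far compound 1 and compound 3 lie past the limit.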